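This account rests on a few compounds, and the source may have more. Where it says the series, first, only, none or still open, it means among the compounds named here.

Within the data shown here, in a functional assay on MCF7 cells (Homo sapiens) for antiproliferative activity, read by MTT assay, with a stated time of 72 h (on this read-out lower numbers stand for stronger inhibition and higher numbers for weaker inhibition), compound 2 `CCN1CCN(c2cc(C)c3cc(NC(=O)c4ccco4)ccc3n2)CC1` gives 41200 nM, the only actual number so far. Compound 1 `CCN1CCN(c2cc(C)c3cc(NC(=O)c4ccccc4Cl)ccc3n2)CC1` reads > 50000 nM, which is a limit. Compound 3 `CCN1CCN(c2cc(C)c3cc(NC(=O)c4ccc(Cl)c(Cl)c4)ccc3n2)CC1` follows from compound 2 through (3,4-dichlorophenyl in place of furan-2-yl on a carbonyl carbon). Among the measured compounds shown here, the sole measured step bearing on this change, an at least 1.2-fold lower number from compound 1 to compound 2 (0.08 log units; that floor lies within the scatter), also exchanges a phenyl group for furan-2-yl on that carbonyl carbon, and it rests on (the limit of > 50000 nM in this assay, at which 1 of the 2 values shown sits). For the measured compounds named here, with that as the only guide, the expected change in this assay is a 1.0-fold higher number from compound 2 to compound 3 (0.01 log units; within the scatter), so no shift beyond the scatter is expected. Compound 3 is estimated at 42000 nM, with an expected range of 15000 nM to 50000 nM.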

Compound 3, half-maximal inhibitory concentration: 1380 nM
Compound 3: middle estimate off by 30-fold (1.48 log units), on the high side, outside the stated range (below it).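

On the carbonyl carbon, the choice of ring proves to matter in this assay: 3,4-dichlorophenyl in place of furan-2-yl gives a 30-fold lower number from compound 2 to compound 3 (1.48 log units; beyond the scatter), a shift beyond the scatter that the earlier step did not reveal. The same group in place of 2-chlorophenyl gives an at least 36-fold lower number from compound 1 to compound 3 (1.55 log units; beyond the scatter), so a chlorinated phenyl group alone does not ensure the lower number. That second step is only a floor, resting on a limit: the limit of > 50000 nM in this assay, at which 1 of the 3 values shown sits.

From the compounds shown here alone, what stays open is which of the two chlorines carries the gain. Going by these compounds, it is also open whether a methoxy group or a nitrile on the phenyl ring could stand in for them.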